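Imidazole TRPV1 antagonists: replacing a methyl with an amide

The source may hold more compounds than are shown below. What is called first, only, known or untested is meant among the compounds shown, and "the series" means these compounds.

Measured so far:
Compound 1 `FC(F)(F)c1cccc(-c2[nH]c(N3CCN(c4ncccc4C(F)(F)F)CC3)nc2-c2ccccc2)c1`: 1240 nM
Compound 2 `Cc1nc(N2CCN(c3ncccc3C(F)(F)F)CC2)[nH]c1-c1ccc(C(F)(F)F)cc1`: 628 nM
Compound 3 `OCc1cnc(N2CCN(c3nc(-c4ccccc4)c(-c4ccc(C(F)(F)F)cc4)[nH]3)CC2)c(Cl)c1`: 90 nM

These three compounds were tested in a functional assay on CHO cells for antagonist activity at transient receptor potential cation channel subfamily V member 1 (Rattus norvegicus), read by calcium flux; on this read-out lower numbers stand for stronger inhibition and higher numbers for weaker inhibition. Compound 1 gives 1240 nM and compound 2 gives 628 nM, two numbers that fall within the scatter of each other, so no order can be read between them. For the measured compounds named here, compound 3, with 90 nM, stands well apart from both, beyond the scatter, as the only compound of the three with a clearly lower number.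

Compound 4 `O=C(NCC1CCCCN1)c1nc(N2CCN(c3ncccc3C(F)(F)F)CC2)[nH]c1-c1ccc(C(F)(F)F)cc1` has not yet been measured in this assay. It is built from compound 2 by a single change: ((piperidin-2-yl)methyl)carbamoyl in place of methyl on an aromatic carbon. A small group gives way to a much larger one that carries a carbonyl and a saturated ring with a nitrogen. Going by the values given here, no pair already measured shows such a change, so nothing here tells its size directly. Because compound 3 reaches 90 nM with a larger substituent pattern, a shift toward a lower number is expected for compound 4, though with wide uncertainty. This expected shift is estimated as the step of a 2.1-fold lower number from compound 2 to compound 4 (0.32 log units; beyond the scatter). Compound 4 is therefore estimated at 300 nM, within a range from 60 nM to 1500 nM.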

Compound 4, half-maximal inhibitory concentration: 2950 nM
Beside the measured number, compound 4's estimate is 9.8-fold (0.99 log units) below it, and the stated range ends below it.
By their numbers in this assay, from the lowest: compound 3; then compounds 2 and 1 (each within the scatter of the next); then compound 4.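

In this assay, putting ((piperidin-2-yl)methyl)carbamoyl in place of methyl on the aromatic carbon next to the ring atom that bears a 4-(trifluoromethyl)phenyl group gives a 4.7-fold higher number from compound 2 to compound 4 (0.67 log units; beyond the scatter). For the compounds shown here, this is the first direct reading of a change at this position, and it shows that here the much larger group, with its carbonyl and saturated ring, goes with weaker inhibition, not stronger. Nothing measured here gives a reason for this step.

Going by these compounds alone, the single step changes several features at once, and it remains open whether the carbonyl, the short link or the piperidine ring accounts for it. An unsubstituted carbamoyl group, or a cyclohexylmethyl amide with a carbon in place of the ring nitrogen, would be needed to separate these parts.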